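The compounds below may be only part of what the source reports. "The series", "measured", "known", "first", "only" and "open" are said of these compounds alone.

Measured so far in a functional assay for inhibition of sodium/hydrogen exchanger (Oryctolagus cuniculus); a lower number here means a stronger inhibitor, a higher number a weaker inhibitor:
compound 1 `Cc1cc(-c2ccc(Cl)cc2)c(S(C)(=O)=O)cc1C(=O)N=C(N)N` – 45 nM
compound 2 `Cc1cc(Nc2ccccc2)c(S(C)(=O)=O)cc1C(=O)N=C(N)N` – 21 nM
compound 3 `Cc1cc(Nc2ncccn2)c(S(C)(=O)=O)cc1C(=O)N=C(N)N` – 8.3 nM

Compound 3 gives the lowest number of the three in this assay; compound 2 stands nearest, a 2.5-fold lower number from compound 2 to compound 3 (0.40 log units; beyond the scatter), and compound 1 furthest, a 5.4-fold lower number from compound 1 to compound 3 (0.73 log units; beyond the scatter). The step of a 2.1-fold lower number from compound 1 to compound 2 (0.33 log units; beyond the scatter) lies between them.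

Compound 4 `Cc1cc(C#N)c(S(C)(=O)=O)cc1C(=O)N=C(N)N` is the next candidate. Its change from compound 3: cyano in place of (pyrimidin-2-yl)amino on an aromatic carbon.

Among the measured compounds shown here, none of the measured steps covers this change directly. All three steps swap one ring-bearing group for another at the same aromatic carbon, and the two steps that move toward compound 3, a 5.4-fold lower number from compound 1 to compound 3 (0.73 log units; beyond the scatter) and a 2.5-fold lower number from compound 2 to compound 3 (0.40 log units; beyond the scatter), show that the identity of that group shifts the number by a modest margin in each direction. The cyano group of compound 4 brings no ring at all, so the numbers of compounds 1, 2 and 3 only show that this position is sensitive, not where a small substituent will land. Since every ring-bearing group measured so far gave a lower number than compound 1, the safer expectation is a higher number for compound 4 than for compound 3, with wide uncertainty.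

For compound 4 the expected step is a 6.0-fold higher number from compound 3 to compound 4 (0.78 log units; beyond the scatter). The estimate for compound 4 in this assay is 50 nM, within the range 15 nM to 170 nM.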

Compound 4, half-maximal inhibitory concentration: 70 nM
For compound 4 the middle estimate is 1.4-fold (0.15 log units) below the measured one; the measured number falls inside the stated range.
By their numbers in this assay, from the lowest: compound 3; then compound 2; then compounds 1 and 4 (each within the scatter of the next).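

Compound 4 shows that a ring is not needed at this aromatic carbon for a number in the range of compound 1, since cyano and 4-chlorophenyl are not separated: a 1.6-fold higher number from compound 1 to compound 4 (0.19 log units; within the scatter). In this assay the two ring-bearing groups linked through nitrogen both give lower numbers than cyano, with a 3.3-fold higher number from compound 2 to compound 4 (0.52 log units; beyond the scatter) and the larger 8.4-fold higher number from compound 3 to compound 4 (0.93 log units; beyond the scatter), so the order among these groups does not follow the presence of a ring alone, and compound 1 goes against any such reading. No measurement shown here bears on the cause of these differences.

The compounds shown leave open whether the linking nitrogen alone goes with the lower numbers, which a plain amino group or a methylamino group on this carbon would test, and whether an unsubstituted phenyl attached directly would stay with compound 1. Also open, as far as these compounds go, is whether other small groups without a ring, such as chloro or methoxy, would fall with compound 4 or nearer to compound 3.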